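The source may report more compounds than this note shows. Statements on the series, on what has been measured and on what is new or still open speak of the compounds shown alone.

Of the compounds shown here, three have been tested in an ADME assay on HaCaT cells (Homo sapiens) for inhibition, read by sulforhodamine B assay, with a stated time of 48 h; a lower number here means a stronger inhibitor of growth, a higher number a weaker inhibitor of growth. Compound 1 `C=C(C)[C@@H]1CC=C(Cn2cc(COc3cccc(C4NC(=O)NC(C)=C4C(C)=O)c3)nn2)CC1` gives 116000 nM. Compound 2 `C=C(C)[C@@H]1CC=C(Cn2cc(COc3cc(C4NC(=O)NC(C)=C4C(C)=O)ccc3OC)nn2)CC1` gives 486000 nM. Compound 3 `C=C(C)[C@@H]1CC=C(Cn2cc(COc3cccc(C4NC(=O)NC5=C4C(=O)CC(C)(C)C5)c3)nn2)CC1`, built on a different core, gives 36400 nM; how its core differs from that of compound 1 is not broken down here. Among the three, compound 3 has the lowest number, with compound 1 nearest and compound 2 furthest.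

Compound 2 differs from compound 1 in one place only (methoxy in place of hydrogen on an aromatic carbon). That change produced a 4.2-fold higher number from compound 1 to compound 2 (0.62 log units; beyond the scatter), so the compound with the methoxy group was the weaker inhibitor of growth.

Compound 4 `C=C(C)[C@@H]1CC=C(Cn2cc(COc3cc(C4NC(=O)NC5=C4C(=O)CC(C)(C)C5)ccc3OC)nn2)CC1` has not yet been measured in this assay. It is related to compound 3 exactly as compound 2 is related to compound 1 (methoxy in place of hydrogen on an aromatic carbon). The change is the same, and it sits at the same kind of place on the ring. Among the measured compounds shown here, with this change seen once so far, the expectation for compound 4 rests on the single step it gave between compound 1 and compound 2, shifted onto the core of compound 3.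

Compound 4 is therefore estimated to give a higher number than compound 3, a step of about a 3.6-fold higher number from compound 3 to compound 4 (0.55 log units; beyond the scatter), because the same change gave a 4.2-fold higher number from compound 1 to compound 2 (0.62 log units; beyond the scatter). The estimate for compound 4 in this assay is 130000 nM, with a likely range from 55000 nM to 320000 nM.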

Compound 4, concentration for total growth inhibition: 451000 nM
Compound 4: the middle estimate sits 3.5-fold (0.54 log units) below what was measured, outside the stated range (above it).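

In this assay, methoxy in place of hydrogen on an aromatic carbon again gave a weaker inhibitor of growth on the second core, with a 12-fold higher number from compound 3 to compound 4 (1.09 log units; beyond the scatter), so the direction of the change carried over from the core of compound 1 to the core of compound 3. The size of the step did not carry over, and the gap between the two steps is larger than repeated measurements would be expected to produce: the same change on two cores in this assay, a 4.2-fold higher number (0.62 log units; beyond the scatter) from compound 1 to compound 2 and a 12-fold higher number (1.09 log units; beyond the scatter) from compound 3 to compound 4, 3.0-fold (0.47 log units) apart, beyond the scatter of two such steps This shows that the core can affect how much this change matters in this series, but two cores give no reason for the difference and no basis for predicting the size of the step, or even its direction, on a third core.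

The compounds shown leave open whether other groups on the same aromatic carbon, such as a hydroxyl or a longer ethoxy chain, would also give a weaker inhibitor of growth and differ in size between the two cores. They also leave open how methoxy would behave on other carbons of this ring.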